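Swapping dimethoxyphenyl for difluorophenyl on the chalcone carbonyl

A few compounds are considered here, and "the series" means these few. Any claim that something is new, unique, unknown or untested is made for them only; others in the source may bear on it.

Three compounds share one core and differ only in the aryl group attached to the carbonyl carbon. Compound 1 `COc1cc(-c2cc(/C=C/C(=O)c3ccc(N)cc3)[nH]n2)cc(OC)c1OC` gives 2910 nM in a functional assay on MDA-MB-468 cells (Homo sapiens) for inhibition, read by sulforhodamine B assay, with a stated time of 48 h; on this read-out lower numbers stand for stronger inhibition of growth and higher numbers for weaker inhibition of growth. Compound 2 `COc1cc(-c2cc(/C=C/C(=O)c3ccc(Cl)c(Cl)c3)[nH]n2)cc(OC)c1OC` gives 7220 nM in this assay. Compound 3 `COc1ccc(C(=O)/C=C/c2cc(-c3cc(OC)c(OC)c(OC)c3)n[nH]2)cc1OC` gives 2180 nM, the lowest number of the three; the gap to compound 1 lies within the scatter, while a 3.3-fold lower number from compound 2 to compound 3 (0.52 log units; beyond the scatter) stands beyond it.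

Compound 4 `COc1cc(-c2cc(/C=C/C(=O)c3ccc(F)c(F)c3)[nH]n2)cc(OC)c1OC` carries the change (3,4-difluorophenyl in place of 3,4-dimethoxyphenyl on a carbonyl carbon). The step most like this one is a 3.3-fold lower number from compound 2 to compound 3 (0.52 log units; beyond the scatter), read in reverse: removing the two acceptor-bearing methoxy groups in favour of two halogens went with a weaker result. The step of a 2.5-fold higher number from compound 1 to compound 2 (0.39 log units; beyond the scatter) also shows two halogens giving a higher number than a group with a heteroatom. Fluorine is not chlorine, so a smaller change is expected, likely toward a higher number, landing between compound 3 and compound 2. For compound 4 the expected step is a 2.1-fold higher number from compound 3 to compound 4 (0.31 log units; beyond the scatter), giving an estimate of 4500 nM, within a range from 2000 nM to 10000 nM.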

Compound 4, concentration for total growth inhibition: 9470 nM
The estimate for compound 4 lay 2.1-fold (0.32 log units) below the measured number; the range from low to high includes it.
By their numbers in this assay, from the lowest: compounds 3 and 1 (each within the scatter of the next); then compounds 2 and 4 (each within the scatter of the next).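

In this assay the 3,4-difluorophenyl group brings no gain over 3,4-dichlorophenyl on the carbonyl carbon: the data show a 1.3-fold higher number from compound 2 to compound 4 (0.12 log units; within the scatter) and so cannot tell these two compounds apart. The fluorine compound also sits clear of the two compounds without halogens, with a 4.3-fold higher number from compound 3 to compound 4 (0.64 log units; beyond the scatter) and a 3.3-fold higher number from compound 1 to compound 4 (0.51 log units; beyond the scatter) in the same direction, so the higher number seen earlier with the two chlorines is not special to chlorine and appears with a second pair of halogens. No measurement shown here bears on the reason for this.

Going by these compounds, what remains open is whether the lower numbers depend on the methoxy and amino groups themselves or simply on the absence of halogens. A plain phenyl or a 4-hydroxyphenyl at this position would test that.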